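The compounds below may be only part of what the source reports. "The series", "measured", "known", "first", "only" and "open" are said of these compounds alone.

In a functional assay on RAW264.7 cells (Mus musculus) for inhibition, read by ELISA, with a stated time of 24 h (a higher number here means that more compound is needed for the effect, a lower number that less compound is needed), two esters built on the same core have been measured so far. Among the measured compounds shown here, compound 1 (`CC/C=C\C[C@H]1C(=O)C=C[C@H]1CC(=O)OCCCCC`) gives 25000 nM, and compound 2 (`CC/C=C\C[C@H]1C(=O)C=C[C@H]1CC(=O)OC(C)C`) gives 20000 nM, so compound 2 lies within the scatter of the only other number available. The next structure, compound 3 (`CC/C=C\C[C@H]1C(=O)C=C[C@H]1CC(=O)OC1CCCCC1`), has cyclohexyl in place of isopropyl on an oxygen next to a carbonyl group. For the measured compounds named here, only one measured step bears on this place: a 1.3-fold lower number from compound 1 to compound 2 (0.10 log units; within the scatter), with isopropyl in place of pentyl. That single pair shows no shift beyond the scatter, although it holds no ring at this oxygen, so the guidance is thin. With that step as the only reference, no step beyond the scatter is expected in this assay, and the expected step is no change at the digits printed from compound 2 to compound 3 (within the scatter). For compound 3 the estimated value is 20000 nM, within an expected range of 9000 nM to 45000 nM.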

Compound 3, half-maximal effective concentration: 22000 nM
Compound 3: the middle estimate sits 1.1-fold (0.04 log units) below what was measured; the measured number falls inside the stated range.
By their numbers in this assay, from the lowest: compounds 2, 3 and 1 (each within the scatter of the next).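

Compound 3 carries the only ring among these esters on the oxygen next to a carbonyl group, and in this assay that ring does not set it apart from the open-chain groups: cyclohexyl in place of isopropyl gives a 1.1-fold higher number from compound 2 to compound 3 (0.04 log units; within the scatter) and cyclohexyl in place of pentyl gives a 1.1-fold lower number from compound 1 to compound 3 (0.06 log units; within the scatter) as the second step. Isopropyl, pentyl and cyclohexyl therefore read alike at this oxygen, although this holds only for these three compounds. Nothing measured here explains this lack of separation.

Going by these compounds, all three groups are made of carbon and hydrogen alone, so it remains open how a chain ending in an amine, or the free carboxylic acid, would read in this assay. A phenyl ring at this oxygen is equally unresolved.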